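Dimethylaminoethyl in Place of Butyl on a Shared Core

A few compounds are considered here, and "the series" means these few. Any claim that something is new, unique, unknown or untested is made for them only; others in the source may bear on it.

Compound 1, `CCCCN1C(=O)NC2(CSC3=C2C(=O)c2ccccc2C3=O)C1=O`: 178 nM in a functional assay on MCF7 cells (Homo sapiens) for inhibition; on this read-out lower numbers stand for stronger inhibition and higher numbers for weaker inhibition
Compound 2, `CCC(C)N1C(=O)NC2(CSC3=C2C(=O)c2ccccc2C3=O)C1=O`: 178 nM in this assay
Compound 3, `O=C1C2=C(C(=O)c3ccccc31)C1(CS2)NC(=O)N(CCO)C1=O`: 69 nM in this assay

Compound 1 stands level with compound 2 in this assay; together they give the highest numbers of the three, and compound 3 stands apart with a lower number. Compound 4, `CN(C)CCN1C(=O)NC2(CSC3=C2C(=O)c2ccccc2C3=O)C1=O`, differs from compound 1 in one place: dimethylamino in place of ethyl on a saturated chain carbon, two bonds along the chain from an amide-type nitrogen in a ring. Within the data shown here, two measured steps bear on this change. Altering the shape of the chain on the ring nitrogen without adding any new kind of atom gave no change at the digits printed from compound 1 to compound 2 (within the scatter). Placing a hydroxy on the same saturated chain carbon gave a 2.6-fold lower number from compound 1 to compound 3 (0.41 log units; beyond the scatter). The dimethylamino of compound 4 enters at that same place and, like the hydroxy of compound 3, brings one hydrogen-bond acceptor, though without a donor and with one more heavy atom. Because a 2.6-fold lower number from compound 1 to compound 3 (0.41 log units; beyond the scatter) came from a change at this very place, a modest lowering of the number is expected for compound 4 as well, with wide uncertainty since the two groups are not the same. I expect a 1.6-fold lower number from compound 1 to compound 4 (0.21 log units; within the scatter). For compound 4 the estimated value in this assay is 110 nM, with a likely range from 45 nM to 300 nM.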

Compound 4, half-maximal inhibitory concentration: 32 nM
Estimate against measurement, compound 4: 3.4-fold (0.54 log units) above, outside the stated range (below it).
By their numbers in this assay, from the lowest: compound 4; then compound 3; then compounds 1 and 2 (each within the scatter of the next).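

In this assay, the change at this saturated chain carbon reaches further than compound 3 alone could show: dimethylamino in place of ethyl gives a 5.6-fold lower number from compound 1 to compound 4 (0.75 log units; beyond the scatter) and, with the branched sec-butyl as the starting point, 2-(dimethylamino)ethyl gives a 5.6-fold lower number from compound 2 to compound 4 (0.75 log units; beyond the scatter) on the same shared core. Swapping one of the two new groups for the other also matters, with a 2.2-fold lower number from compound 3 to compound 4 (0.33 log units; beyond the scatter) as dimethylamino replaces hydroxy, so the identity of the group at this place counts, and a hydrogen-bond donor in the entering group is not needed for the lower number. Nothing available here accounts for this order among the groups.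

The compounds shown leave open whether any amine at this place would serve, for instance a primary amine in place of dimethylamino, or whether a carboxylic acid on the same carbon would move the number in the opposite direction. They also leave open how the number responds to distance, since a longer chain between the amide-type nitrogen in the ring and the dimethylamino could give either a lower or a higher number.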